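This account rests on a few compounds, and the source may have more. Where it says the series, first, only, none or still open, it means among the compounds named here.

Measured so far: compound 1 `O=C(/C=C/c1cn([C@@H]2C[C@@H](C(=O)O)N(Cc3ccccc3)C2)nn1)NO`, 12%; compound 2 `O=C(/C=C/c1cn([C@@H]2C[C@H](C(=O)O)N(CCCc3ccccc3)C2)nn1)NO`, 11%; compound 3 `O=C(/C=C/c1cn([C@@H]2C[C@H](CO)N(Cc3ccccc3)C2)nn1)NO`, < 10%.

All three were tested in an assay on Sf9 cells for inhibition of histone deacetylase 11 (Homo sapiens), read by fluorescence, tested at 0.5 uM; on this read-out lower numbers stand for less inhibition and higher numbers for more inhibition at the one concentration tested (going by the name of the read-out). Compound 1 gives 12% and compound 2 gives 11%, two values that lie within the scatter of each other. For compound 3 only a limit of the assay is reported, < 10%. Compound 3 therefore stands at the floor of the numbers shown, where (the limit of < 10% in this assay, at which 1 of the 3 values shown sits). Compound 4 is `O=C(/C=C/c1cn([C@@H]2C[C@H](C(=O)O)N(Cc3ccccc3)C2)nn1)NO` and has not yet been measured. It differs from compound 3 by carboxy in place of hydroxymethyl on a saturated ring carbon. Going by the values given here, no step between measured compounds is available for comparison. A small rise a number at least 2 percentage points higher from compound 3 to compound 4 (that floor lies within the scatter) is expected, because compound 1 gives 12% and compound 2 gives 11% with the same carboxy group. Compound 4 is estimated at 12%, with a range from 5% to 20%.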

Compound 4, a percentage reported as inhibition, at one concentration (the size of the read-out at that concentration, not a potency): < 10%
Compound 4 ended at the assay's limit; the forecaster's own chance of this, stated with the estimate: 30%; middle value at least 2 percentage points from the limit.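

In this assay, the change from hydroxymethyl to carboxy on this saturated ring carbon cannot be read, since compound 3 and compound 4 both sit at a limit: the limit of < 10% in this assay, at which 2 of the 4 values shown sit. New here is a change of configuration alone at this carbon: the fact that compounds 1 and 4 differ only in the configuration as drawn Turning that stereocentre from S to R gives a number at least 2 percentage points lower from compound 1 to compound 4 (that floor lies within the scatter), and the change in the chain on the ring nitrogen gives a number at least 1 percentage points lower from compound 2 to compound 4 (that floor lies within the scatter).

From the compounds shown here alone, what an amine or a methyl ester on this ring carbon would give in this assay stays open, as does any true difference between compound 3 and compound 4.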